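The source may hold more compounds than are shown below. What is called first, only, known or untested is meant among the compounds shown, and "the series" means these compounds.

Compound 1 `COc1ccc2c(=O)c(/C=C/C(=O)Nc3ccccc3)coc2c1` is tested in a functional assay (QGY7701 cells, Homo sapiens) for inhibition, read by MTT assay, with a stated time of 48 h (a lower number here means a stronger inhibitor, a higher number a weaker inhibitor), and gives 14000 nM. Among the three numbers so far it stands second highest, though its gaps to both neighbours fall within the usual scatter: compound 2 `Cc1ccccc1NC(=O)/C=C/c1coc2cc(O)ccc2c1=O` gives 9320 nM in this assay, and compound 3 `Cc1ccc(CNC(=O)/C=C/c2coc3cc(O)ccc3c2=O)cc1` gives 24900 nM. Compound 4 `COc1ccc2c(=O)c(/C=C/C(=O)NCc3ccccc3F)coc2c1` arises from compound 1 by one change, (2-fluorobenzyl in place of phenyl on an amide-type nitrogen). Among the measured compounds shown here, one measured step bears on it, a 2.7-fold higher number from compound 2 to compound 3 (0.43 log units; beyond the scatter), the same kind of exchange on an amide-type nitrogen, which gave a modest rise beyond the scatter. A rise of similar size is therefore expected for compound 4, with a 2.0-fold higher number from compound 1 to compound 4 (0.30 log units; within the scatter). Compound 4 is estimated at 28000 nM, expected to lie between 11000 nM and 70000 nM.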

Compound 4, half-maximal inhibitory concentration: 34000 nM
Beside the measured number, compound 4's estimate is 1.2-fold (0.08 log units) below it; the measured number falls inside the stated range.
By their numbers in this assay, from the lowest: compounds 2, 1, 3 and 4 (each within the scatter of the next, the first and the last beyond it).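

In this assay, the exchange on the amide-type nitrogen gives a 2.4-fold higher number from compound 1 to compound 4 (0.39 log units; beyond the scatter). Among the compounds shown here, a rise beyond the scatter had so far been seen only as a 2.7-fold higher number from compound 2 to compound 3 (0.43 log units; beyond the scatter), so this position now shows one on the core of compound 1 as well, and with 2-fluorobenzyl as the entering group. Nothing shown gives a reason for this rise. The compounds shown leave open whether the rise belongs to the benzyl part or to the fluorine. They also leave open how a longer chain or an amine on this nitrogen would read.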